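What tert-butyl may do to compound 1

The compounds below may be only part of what the source reports. "The series", "measured", "known", "first", "only" and "open" are said of these compounds alone.

In a functional assay on MDA-MB-231 cells (Homo sapiens) for antiproliferative activity, read by MTT assay, with a stated time of 24 h (on this read-out lower numbers stand for stronger inhibition and higher numbers for weaker inhibition), compound 1 (`O=C(O)CC(NC(=O)c1ccc(Cl)cc1Cl)c1ccccc1`) stands at 67200 nM and compound 2 (`N#Cc1ccc(S(=O)(=O)NC(CC(=O)O)c2ccccc2)cc1`) at 48700 nM within the scatter of each other. Compound 3 (`O=C(O)CC(NS(=O)(=O)c1ccc(OC(F)(F)F)cc1)c1ccccc1`) reads > 100000 nM and this is a limit of the assay, not a number.

Compound 4 (`CC(C)(C)c1ccc(C(CC(=O)O)NC(=O)c2ccc(Cl)cc2Cl)cc1`) has not yet been measured. It differs from compound 1 by a single change, tert-butyl in place of hydrogen on an aromatic carbon, para to a large group (tert-butyl in place of hydrogen on an aromatic carbon). Going by the values given here, no measured step introduces this group. Among the compounds with values here, the only step to hand is an at least 2.0-fold higher number from compound 2 to compound 3 (0.31 log units; beyond the scatter) for trifluoromethoxy in place of cyano on an aromatic carbon. It lies beyond the scatter, but it swaps one substituent for another and so is a loose guide at best. That step reaches the limit of > 100000 nM in this assay, at which 1 of the 3 values shown sits, and therefore gives a bound, not a size.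

A shift to a higher number would fit that one step, but the evidence does not fix a direction. The expected step of a 1.0-fold higher number from compound 1 to compound 4 (0.02 log units; within the scatter) is therefore none beyond the scatter. In this assay compound 4 is estimated at 70000 nM (expected range 25000 nM to 100000 nM).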

Compound 4, half-maximal inhibitory concentration: 67800 nM
Estimate against measurement, compound 4: 1.0-fold (0.01 log units) above, and the stated range covers the measured number.
By their numbers in this assay, from the lowest: compounds 2, 1 and 4 (each within the scatter of the next). At a limit, above all of these: compound 3.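

In this assay, tert-butyl in place of hydrogen on an aromatic carbon, para to a large group, comes out as a 1.0-fold higher number from compound 1 to compound 4 (0.00 log units; within the scatter), so this place on the core of compound 1 takes a group of 4 heavy atoms with no shift beyond the scatter. This is the first step shown at this place and the first that puts a group in place of hydrogen, whereas the earlier step swapped one substituent for another elsewhere in the structure. Unlike that earlier step, this one can be read as a size and not as a bound, for only compound 3 stands at a limit, which is not a number: the limit of > 100000 nM in this assay, at which 1 of the 4 values shown sits.

The compounds shown carry only hydrogen or tert-butyl at this place, so they leave open how an amine, a carboxylic acid or a longer chain would read there. They also leave open whether tert-butyl at this place would read the same way on compound 2, and whether any group here could move the number beyond the scatter in either direction.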